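Changing the group on sulfur in compound 2

A few compounds are considered here, and "the series" means these few. Any claim that something is new, unique, unknown or untested is made for them only; others in the source may bear on it.

In a functional assay on SW-620 cells (Homo sapiens) for cytotoxicity, read by MTT assay, with stated times of 4 h and 72 h, tested at 2 uM (on this read-out lower numbers stand for stronger inhibition and higher numbers for weaker inhibition), compound 2 (`Cc1cc(Nc2ccc(C(=O)/C=C/c3ccc4ccccc4c3)cc2)n2nc(SC(=O)c3csc4ccc(Cl)cc34)nc2n1`) gives 35 nM and compound 1 (`Cc1cc(Nc2ccc(C(=O)/C=C/c3ccc4ccccc4c3)cc2)n2nc(SCc3cccc4ccccc34)nc2n1`) gives 68 nM, two values within the scatter of each other. Compound 3 (`Cc1cc(Nc2ccc(C(=O)/C=C/c3ccc(C(F)(F)F)cc3)cc2)n2nc(SCc3nc4ccccc4[nH]3)nc2n1`) differs from compound 2 in more than one place, so it says little about a single swap, and compound 3 reads a far higher 1850 nM here. Compound 4 (`Cc1cc(Nc2ccc(C(=O)/C=C/c3ccc4ccccc4c3)cc2)n2nc(SCC(=O)c3ccccc3)nc2n1`) carries benzoylmethyl in place of (5-chloro-1-benzothiophen-3-yl)carbonyl on a sulfur. For the measured compounds named here, the only single swap measured at this sulfur gave a 1.9-fold lower number from compound 1 to compound 2 (0.29 log units; within the scatter) and so hints at no large effect. A modest rise is expected, an estimated 2.6-fold higher number from compound 2 to compound 4 (0.41 log units; beyond the scatter) in this assay for this swap. Compound 4 is estimated at 90 nM with 25 nM to 350 nM as the expected range.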

Compound 4, half-maximal inhibitory concentration: 190 nM
For compound 4 the middle estimate is 2.1-fold (0.32 log units) below the measured one; measured number inside the range.
By their numbers in this assay, from the lowest: compounds 2 and 1 (each within the scatter of the next); then compound 4; then compound 3.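

Compounds 1 and 2 differ within the scatter, but this change clearly moves the number: benzoylmethyl gives a 5.4-fold higher number from compound 2 to compound 4 (0.73 log units; beyond the scatter) and so costs activity here. The second comparison, a 2.8-fold higher number from compound 1 to compound 4 (0.45 log units; beyond the scatter) for benzoyl in place of naphthalen-1-yl on the saturated chain carbon, shows that changing only the end group on an otherwise matched chain is enough to raise the number. Nothing available explains why these groups differ.

Going by these compounds, what remains open is how an amine or a carboxylic acid at the end of this chain would read. On these data alone, a longer chain on the sulfur is equally open.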